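The source may report more compounds than this note shows. Statements on the series, on what has been measured and on what is new or still open speak of the compounds shown alone.

Compound 1 `CCC(C)NC(=O)/C=C/c1c(/C=C/c2ccc(OC)cc2)cc(OC)cc1OC` carries a (sec-butyl)amino group on the carbonyl carbon of its side chain. In a functional assay on A549 cells (Homo sapiens) for inhibition, read by MTT assay, with a stated time of 48 h (on this read-out higher numbers stand for weaker inhibition and lower numbers for stronger inhibition), compound 1 gives 3950 nM, the lowest of the two numbers recorded so far, though its nearest neighbour sits within the scatter. For the measured compounds named here, that neighbour is compound 2 `COc1ccc(/C=C/c2cc(OC)cc(OC)c2/C=C/C(=O)N2CCN(C)CC2)cc1`, which in this assay gives 4510 nM; the single step of a 1.1-fold higher number from compound 1 to compound 2 (0.06 log units; within the scatter) shows that swapping the (sec-butyl)amino group for a cyclic amine on the carbonyl carbon left the number essentially unchanged.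

Compound 3 `COc1ccc(/C=C/c2cc(OC)cc(OC)c2/C=C/C(=O)N2CCCCC2C)cc1` is the next variation on the same theme: 2-methylpiperidin-1-yl in place of (sec-butyl)amino on a carbonyl carbon. Going by the values given here, the only measured step that bears on this change is the one from compound 1 to compound 2, where a different six-membered amine entered at the same place and the number moved only within the scatter. On that basis a shift no larger than the scatter is expected for compound 3, with the estimated step of a 1.1-fold higher number from compound 1 to compound 3 (0.03 log units; within the scatter) in this assay. Compound 3 is therefore expected to give about 4200 nM in this assay, within a range of 2000 nM to 9000 nM.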

Compound 3, half-maximal inhibitory concentration: 5770 nM
Compound 3: the middle estimate sits 1.4-fold (0.14 log units) below what was measured; the range from low to high includes it.
By their numbers in this assay, from the lowest: compounds 1, 2 and 3 (each within the scatter of the next).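

With compound 3, the place on the carbonyl carbon has now held three different amine groups, and in this assay all of them read alike, both against the open-chain group (a 1.5-fold higher number from compound 1 to compound 3 (0.16 log units; within the scatter)) and against the other ring (a 1.3-fold higher number from compound 2 to compound 3 (0.11 log units; within the scatter)). Exchanging (sec-butyl)amino, which carries a hydrogen-bond donor, for 2-methylpiperidin-1-yl, a six-membered non-aromatic ring with more heavy atoms and no donor, therefore stays within the scatter, as does exchanging 4-methylpiperazin-1-yl for that same ring, so the three compounds cannot be ranked on this read-out. No measured evidence is available to explain this result.

The compounds shown leave open whether any group at this place would move the number beyond the scatter, for instance a carboxylic acid, a primary amine or a longer alkyl chain on the amide nitrogen. They also leave open how the number would respond to a change elsewhere on the shared core, such as a hydroxyl group in place of one of its methoxy groups.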